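Swapping the Ring on Sulfur: Compound 3 to Compound 4

This account rests on a few compounds, and the source may have more. Where it says the series, first, only, none or still open, it means among the compounds named here.

Compound 1 `Cn1c(-c2ccc(NC(=O)CCl)cc2)nc(-c2ccccc2)c1-c1ccccc1` gives 7.2% in a functional assay on HT-29 cells (Homo sapiens) for cytotoxicity, read by MTT assay, with a stated time of 24 h, tested at 0.64 ug/mL; on this read-out lower numbers stand for a weaker effect and higher numbers for a stronger effect at the one concentration tested.
Compound 2 `Cn1c(-c2ccc(NC(=O)CSc3nc4cc(Cl)ccc4o3)cc2)nc(-c2ccccc2)c1-c1ccccc1` gives 11.9%.
Compound 3 `Cn1cnnc1SCC(=O)Nc1ccc(-c2nc(-c3ccccc3)c(-c3ccccc3)n2C)cc1` gives 32%.

Compound 3 stands highest of the three, beyond the scatter from both others. Compound 4 `Cc1nnc(SCC(=O)Nc2ccc(-c3nc(-c4ccccc4)c(-c4ccccc4)n3C)cc2)s1` differs from compound 3 only in 5-methyl-1,3,4-thiadiazol-2-yl in place of 4-methyl-4H-1,2,4-triazol-3-yl on a sulfur, on a sulfur whose other neighbour is a saturated chain carbon. The measured step most alike in kind is a number 20.1 percentage points higher from compound 2 to compound 3 (beyond the scatter), where one ring on that sulfur replaced another; a number 24.8 percentage points higher from compound 1 to compound 3 (beyond the scatter) touches the same place from a different start. Neither shows how the entering ring compares with the one it replaces, so the step is expected to be small, a number 5 percentage points lower from compound 3 to compound 4 (within the scatter), probably within the scatter. Compound 4 is therefore estimated at 27%, in a range from 10% to 48%.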

Compound 4, a percentage reported as activity, at one concentration (the size of the read-out at that concentration, not a potency): 34.8%
Compound 4: the middle estimate sits 7.8 percentage points below what was measured; measured number inside the range.
By their numbers in this assay, from the lowest: compounds 1 and 2 (each within the scatter of the next); then compounds 3 and 4 (each within the scatter of the next).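

In this assay the 5-methyl-1,3,4-thiadiazol-2-yl ring on the sulfur matches the 4-methyl-4H-1,2,4-triazol-3-yl ring, with a number 2.8 percentage points higher from compound 3 to compound 4 (within the scatter) for this exchange of one five-membered aromatic ring for another. The gain over the other two compounds also holds with this second ring, which gives a number 22.9 percentage points higher from compound 2 to compound 4 (beyond the scatter) and a number 27.6 percentage points higher from compound 1 to compound 4 (beyond the scatter) as well. No supporting measurement explains these numbers. From the compounds shown here alone, what remains open is whether a ring is needed on the sulfur at all: an amine or a carboxylic acid there, or a longer chain in place of the saturated chain carbon, could show this.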